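The source may hold more compounds than are shown below. What is called first, only, known or untested is meant among the compounds shown, and "the series" means these compounds.

Working notes on the series. Two compounds have numbers in a functional assay on DU-145 cells (Homo sapiens) for inhibition; on this read-out higher numbers stand for weaker inhibition and lower numbers for stronger inhibition. Compound 1 `Oc1ccc(-c2cc(-c3ccccc3F)cc(-c3cccc(O)c3)n2)cc1` gives 3160 nM in this assay. Compound 2 `Oc1ccc(-c2cc(-c3ccccc3OC(F)(F)F)cc(-c3ccccc3O)n2)cc1` gives 4190 nM in this assay. Compound 2 and compound 1 lie within the usual scatter of each other, so the two are not separated by these measurements.

Compound 3 `Oc1ccc(-c2cc(-c3ccccc3OC(F)(F)F)cc(-c3cccc(O)c3)n2)cc1` is not yet measured. Relative to compound 2 the change is 3-hydroxyphenyl in place of 2-hydroxyphenyl on an aromatic carbon. Compound 1 already carries the 3-hydroxyphenyl group on the shared core, and its number sits within the scatter of that of compound 2, so the values shown give no sign that the hydroxyl position on that ring moves this assay. For the measured compounds named here, no step between measured compounds isolates this change; the expectation for compound 3 is a step of a 1.2-fold lower number from compound 2 to compound 3 (0.08 log units; within the scatter) that stays within the scatter, in no firm direction. Compound 3 is estimated at 3500 nM in this assay, with a range from 1500 nM to 8000 nM.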

Compound 3, half-maximal inhibitory concentration: 7760 nM
Compound 3: middle estimate off by 2.2-fold (0.35 log units), on the low side; measured number inside the range.
By their numbers in this assay, from the lowest: compounds 1, 2 and 3 (each within the scatter of the next, the first and the last beyond it).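

In this assay, 3-hydroxyphenyl in place of 2-hydroxyphenyl with the trifluoromethoxy group held gives a 1.9-fold higher number from compound 2 to compound 3 (0.27 log units; within the scatter) and so, now measured directly, the hydroxyl position on this ring is still not shown to move the read-out. For the compounds shown here, with the 3-hydroxyphenyl group held, trifluoromethoxy in place of fluoro gives a 2.5-fold higher number from compound 1 to compound 3 (0.39 log units; beyond the scatter) as a modest step, the first single change in this set to separate two compounds, with the fluoro compound 1 on the side of stronger inhibition. No measurement shown bears on the reason for this step.

On these data alone, whether the hydroxyl position behaves the same with fluoro in place of trifluoromethoxy remains open. Also open, as far as these compounds go, is how an amine at the hydroxyl position, or a methoxy or chloro group in place of fluoro, would read in this assay on the shared core.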